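From Methyl to 2-Carboxyphenyl on a Carbonyl Carbon

A few compounds are considered here, and "the series" means these few. Any claim that something is new, unique, unknown or untested is made for them only; others in the source may bear on it.

Of the compounds shown here, two sharing one core have been measured so far in an ADME assay on HepG2 2.2.15 cells (Homo sapiens) for cytotoxicity, read by MTT assay; on this read-out lower numbers stand for higher toxicity in this test and higher numbers for lower toxicity in this test. Compound 1 (`C=C1CC[C@@H]2[C@](C)(COC(=O)/C=C/c3ccccc3)[C@H](O)CC[C@@]2(C)[C@@H]1C/C=C1\C=COC1=O`) gives 271000 nM. Compound 2 (`C=C1CC[C@@H]2[C@](C)(COC(C)=O)[C@H](O)CC[C@@]2(C)[C@@H]1C/C=C1\C=COC1=O`) gives 334000 nM, which lies within the usual scatter of the value for compound 1, so the numbers do not separate the two.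

The next structure is compound 3 (`C=C1CC[C@@H]2[C@](C)(COC(=O)c3ccccc3C(=O)O)[C@H](O)CC[C@@]2(C)[C@@H]1C/C=C1\C=COC1=O`), which keeps the core of compound 2 and alters one group: 2-carboxyphenyl in place of methyl on a carbonyl carbon. In short, 2-carboxyphenyl stands in place of methyl on a carbonyl carbon.

Within the data shown here, only one measured step touches this same place, and it is a 1.2-fold higher number from compound 1 to compound 2 (0.09 log units; within the scatter). That step exchanged 2-phenylethenyl and methyl and stayed within the scatter. Among the measured compounds shown here, no measured compound carries 2-carboxyphenyl, so this single step is thin guidance. Going by a 1.2-fold higher number from compound 1 to compound 2 (0.09 log units; within the scatter), a step beyond the scatter is not expected in this assay, in either direction. The expected change is a 1.2-fold lower number from compound 2 to compound 3 (0.06 log units; within the scatter). For compound 3 the estimated value is 290000 nM, with an expected range from 120000 nM to 650000 nM.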

Compound 3, half-maximal cytotoxic concentration: 450000 nM
For compound 3 the middle estimate is 1.6-fold (0.19 log units) below the measured one; the range from low to high includes it.
By their numbers in this assay, from the lowest: compounds 1, 2 and 3 (each within the scatter of the next).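

In this assay, the position on the carbonyl carbon whose other neighbours are oxygen next to a carbonyl group has now carried a much larger change than before: methyl, with 1 heavy atom, gives way to 2-carboxyphenyl, with 9 heavy atoms, an aromatic ring and a hydrogen-bond donor, and the result is still (a 1.3-fold higher number from compound 2 to compound 3 (0.13 log units; within the scatter)). Replacing 2-phenylethenyl with the same group gives the same picture (a 1.7-fold higher number from compound 1 to compound 3 (0.22 log units; within the scatter)), so methyl, 2-phenylethenyl and 2-carboxyphenyl cannot be told apart here, and none of the three compounds goes against this. The data offer no explanation for this flat picture.

What the compounds shown leave open is whether the same holds for other groups on this carbonyl carbon, such as an amine-bearing chain or a longer saturated carbon chain, or when the whole acyl group gives way to a free hydroxyl. They also leave open whether a change elsewhere on the shared core would move the number beyond the scatter, since all three compounds keep that core unchanged.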